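A few compounds are considered here, and "the series" means these few. Any claim that something is new, unique, unknown or untested is made for them only; others in the source may bear on it.

Compound 1, `Oc1ccc(CNc2cc(Br)cc3[nH]ncc23)cc1F`: 52%
Compound 2, `Brc1cc(NCc2ccco2)c2cn[nH]c2c1`: 29%

Among the two compounds measured in an assay for inhibition of Indoleamine 2,3-dioxygenase 1 (Homo sapiens), with a stated time of 1 h, tested at 10 uM (on this read-out higher numbers stand for more inhibition at the one concentration tested (going by the name of the read-out) and lower numbers for less inhibition), compound 2 stands lowest; its nearest neighbour, compound 1, gives a number higher by a gap beyond the usual scatter. Among the measured compounds shown here, no pair of measured compounds differs in only one place, so there is no matched step to lean on.

Compound 3, `Nc1nc(CNc2cc(Br)cc3[nH]ncc23)cs1`, has not been measured. It differs from compound 2 in one respect: 2-amino-1,3-thiazol-4-yl in place of furan-2-yl on a saturated chain carbon bound to a nitrogen on an aromatic ring. The entering group brings one hydrogen-bond donor and three acceptors where the leaving group had none and one. Without a comparable step among the measured compounds, only a cautious expectation is possible: a small rise in this assay for compound 3 relative to compound 2 is expected, the estimated step of a number 11 percentage points higher from compound 2 to compound 3 (beyond the scatter) lying near the edge of the scatter. Compound 3 is thus expected to give about 40%, in a range from 20% to 60%.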

Compound 3, a percentage reported as inhibition, at one concentration (the size of the read-out at that concentration, not a potency): "not active" (no number reported)
Compound 3: no number reported, and the estimate cannot be compared.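

In this assay, among the compounds shown here, compound 3 gives "not active" (no number reported) without a number, so no step from compound 2 can be read. The compounds shown leave open how large any change from furan-2-yl to 2-amino-1,3-thiazol-4-yl is. Nothing shown offers an explanation for this result.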